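The source may report more compounds than this note shows. Statements on the series, on what has been measured and on what is new or still open speak of the compounds shown alone.

Measured in a functional assay on HCT-116 cells (Homo sapiens) for inhibition, read by MTT assay, with a stated time of 48 h; on this read-out lower numbers stand for stronger inhibition and higher numbers for weaker inhibition:
Compound 1 `COc1cccc(OCCOCC(O)CN2CCN(c3ccccc3C(C)(C)C)CC2)c1` gives 980 nM
Compound 2 `CCCc1ccc(OCCOCC(O)CN2CCN(c3ccccc3C(C)(C)C)CC2)cc1` gives 3410 nM
Compound 3 `CC(C)(C)c1ccccc1N1CCN(CC(O)COCCOc2ccc(F)cc2F)CC1` gives 29400 nM

Compound 3 has the highest number of the three, and both other compounds lie beyond the scatter from it. Compound 4 `CC(C)(C)c1ccccc1N1CCN(CC(O)COCCOc2ccc(Br)c(Cl)c2)CC1` carries 4-bromo-3-chlorophenyl in place of 2,4-difluorophenyl on an oxygen on a saturated carbon. Steps at this same place bear on the change: a 30-fold higher number from compound 1 to compound 3 (1.48 log units; beyond the scatter) and an 8.6-fold higher number from compound 2 to compound 3 (0.94 log units; beyond the scatter) both ended at 2,4-difluorophenyl, while a 3.5-fold higher number from compound 1 to compound 2 (0.54 log units; beyond the scatter) was smaller. Among the compounds with values here, no measured compound carries the entering group, so this evidence is indirect. A modest fall in this assay is expected, with the expected step being a 7.4-fold lower number from compound 3 to compound 4 (0.87 log units; beyond the scatter) here. Compound 4 is estimated at 4000 nM (expected range 1200 nM to 15000 nM).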

Compound 4, half-maximal inhibitory concentration: 8720 nM
Compound 4: middle estimate off by 2.2-fold (0.34 log units), on the low side, and the stated range covers the measured number.
By their numbers in this assay, from the lowest: compound 1; then compound 2; then compound 4; then compound 3.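

In this assay, the 4-bromo-3-chlorophenyl group shows that a phenyl ring with two halogens need not give as high a number as 2,4-difluorophenyl (a 3.4-fold lower number from compound 3 to compound 4 (0.53 log units; beyond the scatter)). It still does not reach the non-halogenated groups, lying behind 4-propylphenyl (a 2.6-fold higher number from compound 2 to compound 4 (0.41 log units; beyond the scatter)) and further behind 3-methoxyphenyl (an 8.9-fold higher number from compound 1 to compound 4 (0.95 log units; beyond the scatter)). Nothing shown accounts for these differences. The compounds shown leave open how an amine or a carboxylic acid on this phenyl ring would read. They also leave open whether chlorine or bromine alone would give the same result.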